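The source may report more compounds than this note shows. Statements on the series, on what has been measured and on what is new or still open speak of the compounds shown alone.

Working notes on the benzylsulfanyl series in a functional assay on HeLa cells (Homo sapiens) for cytotoxicity, read by MTT assay, with a stated time of 72 h; on this read-out higher numbers stand for weaker inhibition and lower numbers for stronger inhibition.

Of the compounds shown here, two have numbers so far. Compound 1 `Cc1cc(S(=O)(=O)/N=C(\N)n2nccc2-c2ccccc2)c(SCc2ccc(C(F)(F)F)cc2)cc1Cl` gives 17000 nM in this assay, and compound 2 `Cc1cc(S(=O)(=O)/N=C(\N)n2nccc2-c2ccccc2)c(SCc2cccc3ccccc23)cc1Cl` gives 3000 nM. Among the measured compounds shown here, compound 2 therefore holds the lowest of the two numbers; its only neighbour is compound 1, and the single measured step, a 5.7-fold lower number from compound 1 to compound 2 (0.75 log units; beyond the scatter), is beyond the scatter and modest in size.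

Compound 3 `Cc1cc(S(=O)(=O)/N=C(\N)n2nccc2-c2ccccc2)c(SCc2ccccc2C(F)(F)F)cc1Cl` is not yet measured in this assay. It differs from compound 2 in one place: 2-(trifluoromethyl)phenyl in place of naphthalen-1-yl on a saturated chain carbon bound to a sulfur. For the measured compounds named here, the one step that bears on this change is the reverse of the measured one, in that a trifluoromethyl-bearing phenyl again takes the place of naphthalen-1-yl on a saturated chain carbon bound to a sulfur; but the trifluoromethyl now sits in the 2-position rather than the 4-position, so the earlier step is only a partial guide. On that basis a rise in the number for compound 3 is expected, likely smaller than the measured step and with wide uncertainty, as a 3.0-fold higher number from compound 2 to compound 3 (0.48 log units; beyond the scatter).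

Compound 3 is thus estimated at 9000 nM in this assay, with a range of 3000 nM to 27000 nM.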

Compound 3, half-maximal inhibitory concentration: 20000 nM
Estimate against measurement, compound 3: 2.2-fold (0.35 log units) below; low and high end bracket the measured number.
By their numbers in this assay, from the lowest: compound 2; then compounds 1 and 3 (each within the scatter of the next).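

In this assay, on the saturated chain carbon bound to a sulfur, 2-(trifluoromethyl)phenyl in place of 4-(trifluoromethyl)phenyl gives a 1.2-fold higher number from compound 1 to compound 3 (0.07 log units; within the scatter), so this read-out does not separate the two trifluoromethyl placements. Naphthalen-1-yl therefore holds the lowest number against both trifluoromethyl-bearing groups, and a 6.7-fold higher number from compound 2 to compound 3 (0.82 log units; beyond the scatter) shows that the gap seen in a 5.7-fold lower number from compound 1 to compound 2 (0.75 log units; beyond the scatter) is not tied to the 4-(trifluoromethyl)phenyl group alone. Nothing available offers an explanation for these differences.

Open, as far as these compounds go, is whether the lower number goes with the naphthalen-1-yl group specifically, since an unsubstituted phenyl, a naphthalen-2-yl or a longer chain between the sulfur and the aromatic ring would each test that in a different way. From the compounds shown here alone, with the core shared by all three compounds, it also remains open whether the same picture would hold for a benzyl group carrying a methoxy group, an amine or a carboxylic acid in place of the trifluoromethyl.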